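Amide variation on the arylidene succinimide series

The source may report more compounds than this note shows. Statements on the series, on what has been measured and on what is new or still open speak of the compounds shown alone.

Compound 1 `O=C(Nc1ccccc1)c1cccc(/C=C2\CC(=O)N(c3ccccc3)C2=O)c1` carries an anilide on the shared core. In an ADME assay on HCT-116 cells (Homo sapiens) for cytotoxicity, read by MTT assay, with a stated time of 72 h (on this read-out higher numbers stand for weaker inhibition and lower numbers for stronger inhibition), compound 1 gives > 100000 nM, a limit of the assay rather than a number. Compound 2 `COc1ccc(NC(=O)c2cccc(/C=C3\CC(=O)N(c4ccccc4)C3=O)c2)cc1` adds a methoxy group to that anilide; in this assay compound 2 gives > 100000 nM, again only a limit. Compound 3 `O=C(c1cccc(/C=C2\CC(=O)N(c3ccccc3)C2=O)c1)N1CCCC1` replaces the anilide with a pyrrolidine amide, and in this assay compound 3 gives > 100000 nM, also a limit, so compound 3 stands only at a limit and no number separates it from the two others. Accordingly the steps a step that the two limits leave unreadable from compound 1 to compound 2, a step that the two limits leave unreadable from compound 1 to compound 3 and a step that the two limits leave unreadable from compound 2 to compound 3 cannot be sized because of the limit of > 100000 nM in this assay, at which 3 of the 3 values shown sit.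

Compound 4 `CCOc1ccc(NC(=O)c2cccc(/C=C3\CC(=O)N(c4ccccc4)C3=O)c2)cc1` differs from compound 3 in that ((4-ethoxyphenyl)amino in place of pyrrolidin-1-yl on a carbonyl carbon). The steps from compound 2 to compound 3 and from compound 1 to compound 3 bear on this change, and neither is readable. No step beyond the scatter is therefore expected for a step that the limit leaves unreadable from compound 3 to compound 4. Compound 4 is estimated at 150000 nM, with an expected range from 60000 nM to 400000 nM, most likely reported as a limit.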

Compound 4, half-maximal inhibitory concentration: 84800 nM
For compound 4 the middle estimate is 1.8-fold (0.25 log units) above the measured one; low and high end bracket the measured number.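

In this assay, within the data shown here, compound 4 is the first compound here to give a number rather than a limit, 84800 nM. Set against the pyrrolidine amide, the change reads as an at least 1.1-fold lower number from compound 3 to compound 4 (0.07 log units; that floor lies within the scatter); a methyl added to the methoxy group reads as an at least 1.1-fold lower number from compound 2 to compound 4 (0.07 log units; that floor lies within the scatter), and an ethoxy group on the plain anilide reads as an at least 1.1-fold lower number from compound 1 to compound 4 (0.07 log units; that floor lies within the scatter). These steps are floors and not sizes, because the other compounds stand at a limit: the limit of > 100000 nM in this assay, at which 3 of the 4 values shown sit.

On these data alone, the true size of all three steps therefore remains open, and with it whether the ethoxy group matters at all on this anilide. Also open, as far as these compounds go, is what a longer chain such as butoxy, a dimethylamino group or a carboxylic acid would give on that ring.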